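Pyrazole for isoxazole on the cyclopropylamide series

This account rests on a few compounds, and the source may have more. Where it says the series, first, only, none or still open, it means among the compounds named here.

Compound 2 `Cc1noc(C)c1-c1nn(Cc2ccc(C(=O)NC3CC3)cc2)c(=O)c2ccccc12` gives only a limit in a functional assay on HCT-116 cells (Homo sapiens) for antiproliferative activity, read by MTT assay, with a stated time of 72 h (on this read-out higher numbers stand for weaker inhibition and lower numbers for stronger inhibition), namely > 100000 nM. Compound 3 `Cc1noc(C)c1-c1nn(Cc2ccc(C(=O)NC3CC(C)(C)N([O])C(C)(C)C3)cc2)c(=O)c2ccccc12` gives 36800 nM in this assay, and the step of an at least 2.7-fold lower number from compound 2 to compound 3 (0.43 log units; beyond the scatter) describes the change at the amide. Compound 1 `CN1CCC(NC(=O)c2ccc(Cn3nc(-c4cnn(C)c4)c4ccccc4c3=O)cc2)CC1` gives 69500 nM in this assay. Compound 4 `Cn1cc(-c2nn(Cc3ccc(C(=O)NC4CC4)cc3)c(=O)c3ccccc23)cn1` is compound 2 with 1-methyl-1H-pyrazol-4-yl in place of 3,5-dimethyl-1,2-oxazol-4-yl on an aromatic carbon. Among the compounds with values here, the only measured step, from compound 2 to compound 3, alters the amide and leaves the aryl group untouched, so no measured step bears directly on this change; compound 1 shows what the 1-methyl-1H-pyrazol-4-yl group delivers with another amide, and one of the three values rests at the limit of > 100000 nM in this assay, at which 1 of the 3 values shown sits. No step beyond the scatter is expected, an at least 1.1-fold lower number from compound 2 to compound 4 (0.04 log units; that floor lies within the scatter). Compound 4 is estimated at 90000 nM, with a range from 40000 nM to 300000 nM.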

Compound 4, half-maximal inhibitory concentration: 20100 nM
Beside the measured number, compound 4's estimate is 4.5-fold (0.65 log units) above it; measured number outside the range, below it.
By their numbers in this assay, from the lowest: compounds 4, 3 and 1 (each within the scatter of the next, the first and the last beyond it). At a limit, above all of these: compound 2.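

In this assay, within the data shown here, 1-methyl-1H-pyrazol-4-yl in place of 3,5-dimethyl-1,2-oxazol-4-yl on this aromatic carbon gives an at least 4.9-fold lower number from compound 2 to compound 4 (0.69 log units; beyond the scatter), the first measured step at this position. The size of this step is only a floor, as one end of it is a limit: the limit of > 100000 nM in this assay, at which 1 of the 4 values shown sits.
With 1-methyl-1H-pyrazol-4-yl held in place, cyclopropyl in place of 1-methylpiperidin-4-yl on the amide nitrogen gives a 3.5-fold lower number from compound 1 to compound 4 (0.54 log units; beyond the scatter), so the amide still matters with this aryl group.

Open, from the compounds shown here alone, is whether a pyrazole without the methyl group or a plain phenyl on this carbon would give a lower number. Also open, going by these compounds, is how 1-methyl-1H-pyrazol-4-yl behaves with the amide of compound 3.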